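Phenyl Replaces the Amide Chain on the Sulfonyl

A few compounds are considered here, and "the series" means these few. Any claim that something is new, unique, unknown or untested is made for them only; others in the source may bear on it.

Among the compounds with values here, compound 2 `CC(C)C(=O)NCCS(=O)(=O)NC(=O)c1ccc(Nc2nc(NC3(c4ccc(Cl)cc4)CC3)nc(OCC(F)(F)F)n2)cc1` is the weaker of the two compounds measured so far: in a physicochemical assay for permeability, using PAMPA, at pH 7.4 (a lower number here means that the compound crosses the layer more slowly, a higher number that the compound crosses the layer faster), compound 2 gives 13 nm/s while its nearest neighbour, compound 1 `CC(C)S(=O)(=O)NC(=O)c1ccc(Nc2nc(NC3(c4ccc(Cl)cc4)CC3)nc(OCC(F)(F)F)n2)cc1`, gives 31 nm/s in this assay and the only measured step is a 2.4-fold lower number from compound 1 to compound 2 (0.38 log units; beyond the scatter). Compound 3 `O=C(NS(=O)(=O)c1ccccc1)c1ccc(Nc2nc(NC3(c4ccc(Cl)cc4)CC3)nc(OCC(F)(F)F)n2)cc1` changes the same position again: phenyl in place of 2-((isopropylcarbonyl)amino)ethyl on a sulfonyl sulfur. Because a 2.4-fold lower number from compound 1 to compound 2 (0.38 log units; beyond the scatter) shows that adding the chain with its donor and acceptor lowered the number, removing that chain is expected to raise it by roughly a 2.3-fold higher number from compound 2 to compound 3 (0.36 log units; beyond the scatter). Compound 3 is therefore estimated at about 30 nm/s with a range from 12 nm/s to 75 nm/s.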

Compound 3, apparent permeability: 182 nm/s
The estimate for compound 3 lay 6.1-fold (0.78 log units) below the measured number; measured number outside the range, above it.
By their numbers in this assay, from the lowest: compound 2; then compound 1; then compound 3.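

At this position, the choice of group matters more than the earlier pair suggested: in this assay, phenyl gives a 14-fold higher number from compound 2 to compound 3 (1.15 log units; beyond the scatter) and also a 5.9-fold higher number from compound 1 to compound 3 (0.77 log units; beyond the scatter). Losing the 2-((isopropylcarbonyl)amino)ethyl chain therefore does not account for the whole rise, as compound 3 also stands well above compound 1, which lacks that chain too. The data offer no measured explanation for this rise. Going by these compounds, it remains open whether a pyridine ring would keep the number this high, and whether a methoxy group or a chlorine on the phenyl would raise or lower it.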